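Removal of the aryl methyl group: compound 3 to compound 4

The source may report more compounds than this note shows. Statements on the series, on what has been measured and on what is new or still open speak of the compounds shown alone.

Measured compounds:
Compound 1 `O=C1CCCC2=C1C(c1ccc(F)cc1)C=C(c1ccccc1)N2` — 21.9%
Compound 2 `O=C1CCCC2=C1C(c1ccc(Cl)cc1)C=C(c1ccccc1)N2` — 8.21%
Compound 3 `Cc1ccc(C2=CC(c3ccccc3)C3=C(CCCC3=O)N2)cc1` — 27.7%

All three numbers come from an assay on isolated protein for inhibition of glucose-6-phosphatase catalytic subunit 1 (Homo sapiens), read by inositol phosphate accumulation, with a stated time of 30 min, tested at 100 uM; on this read-out higher numbers stand for more inhibition at the one concentration tested (going by the name of the read-out) and lower numbers for less inhibition. Compound 3 holds the highest of the three numbers. Its nearest neighbour is compound 1, whose value sits within the scatter of that of compound 3, so the two cannot be ordered. Compound 2 lies furthest off, beyond the scatter and lower. For the measured compounds named here, the one step that exists between measured compounds, a number 13.7 percentage points lower from compound 1 to compound 2 (beyond the scatter), concerns a halogen swap and is modest in size.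

Compound 4 `O=C1CCCC2=C1C(c1ccccc1)C=C(c1ccccc1)N2` is not yet measured. It differs from compound 3 by hydrogen in place of methyl on an aromatic carbon.

Going by the values given here, no measured step removes a substituent from the aryl ring, so the chloro-for-fluoro step offers only indirect guidance: it shows that a change on this ring can move the read-out by a modest amount. The series gives no direction for the methyl-to-hydrogen change. The expectation is therefore a step of a number 7.7 percentage points lower from compound 3 to compound 4 (within the scatter) in this assay, which is within the scatter, and compound 4 is estimated at 20% with a range from 5% to 35%.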

Compound 4, a percentage reported as inhibition, at one concentration (the size of the read-out at that concentration, not a potency): "not active" (no number reported)
The entry for compound 4 holds no number; the estimate stays without a comparison.
By their numbers in this assay, from the lowest: compound 2; then compounds 1 and 3 (each within the scatter of the next).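

For the compounds shown here, the entry for compound 4 reads "not active" with no number, so no step from compound 3 to compound 4 can be read. The compounds shown leave open how far the change from 4-methylphenyl to phenyl moves the inhibition read-out. No supporting evidence bears on this result.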